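Hydroxy for Dimethylamino: Cytotoxicity Expectations

The compounds below may be only part of what the source reports. "The series", "measured", "known", "first", "only" and "open" are said of these compounds alone.

Measured compounds:
compound 1 `CC(C)N(Cc1cccc(OCCCCCC(=O)O)c1)C(=O)c1ccc(-c2ccc(Cl)c(Cl)c2)cc1` — > 26000 nM
compound 2 `CCOC(=O)CCCCCOc1cccc(CN(C(=O)c2ccc(-c3cccc(N(C)C)c3)cc2)C(C)C)c1` — > 26000 nM

In an ADME assay on HepG2 cells (Homo sapiens) for cytotoxicity, read by CellTiter-Glo and resazurin assay, with a stated time of 72 h (a lower number here means that less compound is needed, a higher number that more compound is needed for the effect), compound 1 gives > 26000 nM, which is a limit of the assay rather than a number. In this assay compound 2 gives > 26000 nM, again a limit and not a number. Within the data shown here, compound 2 thus stands at the limit of > 26000 nM in this assay, at which 2 of the 2 values shown sit, with no number of its own and no measured step to another compound. Compound 3 `CCOC(=O)CCCCCOc1cccc(CN(C(=O)c2ccc(-c3cccc(O)c3)cc2)C(C)C)c1` is not yet measured; it differs from compound 2 by hydroxy in place of dimethylamino on an aromatic carbon. Among the measured compounds shown here, with both known values sitting at a limit, no measured pair shows how large such a change runs in this assay; the expectation is no change beyond the scatter, so the estimated step that the limit leaves unreadable from compound 2 to compound 3 is small. Compound 3 is therefore expected at about 30000 nM, with a range from 15000 nM to 60000 nM, and most likely again reported only as a limit.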

Compound 3, half-maximal effective concentration: > 26000 nM
Compound 3 gave a limit, no number; the forecaster's own chance of this, stated with the estimate: 80%; the middle value does not contradict the limit.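

Among these compounds, compound 3, like compound 2, gives only a limit and no number in this assay, and no step between the two can be read. The compounds shown leave open what number any of them would reach in this assay, and whether hydroxy in place of dimethylamino shifts it: the limit of > 26000 nM in this assay, at which 3 of the 3 values shown sit.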